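Chloro for Hydrogen on the Pyrazole Aryl Group

A few compounds are considered here, and "the series" means these few. Any claim that something is new, unique, unknown or untested is made for them only; others in the source may bear on it.

Compound 1 `O=C(NC(=S)Nc1ccc(F)cc1)c1cn(-c2ccccc2)nc1-c1ccc(F)cc1`: 3240 nM
Compound 2 `Cc1ccc(NC(=S)NC(=O)c2cn(-c3ccccc3)nc2-c2ccccc2)cc1`: 3960 nM
Compound 3 `COc1ccc(NC(=S)NC(=O)c2cn(-c3ccccc3)nc2-c2ccc(OC)cc2)cc1`: 2570 nM

Of the compounds shown here, three share one core and have been tested in a functional assay on NCI-H460 cells (Homo sapiens) for inhibition, read by CCK-8 assay, with a stated time of 48 h (a higher number here means a weaker inhibitor, a lower number a stronger inhibitor), where compound 1 gives 3240 nM, compound 2 gives 3960 nM, and compound 3 gives 2570 nM. The three numbers lie within the usual scatter of one another, so none of them can be called stronger or weaker than the others on these data. Compound 2 sits among them with a value that differs from compound 1 and from compound 3 by less than repeated measurements would.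

Compound 4 `Cc1ccc(NC(=S)NC(=O)c2cn(-c3ccccc3)nc2-c2ccc(Cl)cc2)cc1` has not yet been measured in this assay. It differs from compound 2 in one place: chloro in place of hydrogen on an aromatic carbon. The change sits on the aromatic ring attached to the core, para to a large group. For the measured compounds named here, no measured pair shows this kind of change, and the three measured compounds, which differ by substituents on the aromatic rings, all give numbers within the scatter. The expectation is therefore a step of no more than the scatter, in either direction, for the step of a 1.2-fold lower number from compound 2 to compound 4 (0.09 log units; within the scatter). For compound 4 the estimated value in this assay is 3200 nM, with a range from 1500 nM to 7000 nM.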

Compound 4, half-maximal inhibitory concentration: 3120 nM
The estimate for compound 4 lay 1.0-fold (0.01 log units) above the measured number; measured number inside the range.
By their numbers in this assay, from the lowest: compounds 3, 4, 1 and 2 (each within the scatter of the next).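

For the compounds shown here, compounds 2 and 4 are the first pair here that differ in one place only, so they give the first direct reading of this position on the shared core. In this assay, going from phenyl to 4-chlorophenyl gives a 1.3-fold lower number from compound 2 to compound 4 (0.10 log units; within the scatter), so on this evidence, a chloro on this aromatic carbon cannot be told apart from a hydrogen. No measurement shown offers an explanation for this result.

Going by these compounds, a single chloro cannot speak for the whole position, so it remains open whether an amine or a carboxylic acid on the same carbon would give a step beyond the scatter. On these data alone, it is also open whether chloro would give a similar step if the substituents elsewhere on the compound were different.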